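The source may hold more compounds than are shown below. What is called first, only, known or untested is meant among the compounds shown, and "the series" means these compounds.

Measured so far:
compound 1, `O=C(N/N=C/c1ccc(Cl)cc1)c1cnccn1`, 56%
compound 2, `O=C(N/N=C/c1ccccc1F)c1cnccn1`, 81%
compound 3, `O=C(N/N=C/c1ccc(Br)cc1)c1cnccn1`, 94%

These three compounds share one core and differ only in the substituent on the aromatic ring that hangs from the hydrazone. In an ADME assay on J774 cells (Mus musculus) for cytotoxicity, read by MTT assay, with a stated time of 48 h, tested at 150 ug/mL (a lower number here means a stronger effect, a higher number a weaker effect of the compound at the concentration tested), compound 2 gives 81%, which is the second highest of the three numbers: compound 3 stands higher, beyond the scatter, and compound 1 lies further away on the lower side, also beyond the scatter. Among the measured pairs only one step is known, a number 38 percentage points higher from compound 1 to compound 3 (beyond the scatter), a large rise for a swap of one halogen for another.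

Compound 4, `COc1ccccc1/C=N/NC(=O)c1cnccn1`, has not yet been measured in this assay. It differs from compound 2 by methoxy in place of fluoro on an aromatic carbon, placed ortho to a large group. For the measured compounds named here, no measured step covers a methoxy for fluoro exchange, so the one known step, which concerns bromo for chloro, does not bear on it directly; it only shows that a single change on this ring can move the number a great deal. With that in mind, and with the three measured values spanning a wide band, the expectation for compound 4 is a modest rise, a number 3 percentage points higher from compound 2 to compound 4 (within the scatter), which the scatter could well swallow. Compound 4 is therefore estimated at 84%, between 58% and 100%.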

Compound 4, a percentage reported as activity, at one concentration (the size of the read-out at that concentration, not a potency): 97%
Beside the measured number, compound 4's estimate is 13 percentage points below it; low and high end bracket the measured number.
By their numbers in this assay, from the lowest: compound 1; then compound 2; then compounds 3 and 4 (each within the scatter of the next).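

In this assay, putting methoxy in place of fluoro on an aromatic carbon, ortho to a large group, gives a number 16 percentage points higher from compound 2 to compound 4 (beyond the scatter), a step that lies beyond the scatter and points towards a weaker effect at the concentration tested. For the compounds shown here, the only earlier step was an exchange of one halogen for another at a different place on the ring, so this is the first sign that the number also responds to a change at this position, and to a change from a halogen to a group with an oxygen. The data shown offer no measurement that would explain this step, and its size remains an observation without a known cause.

Still open, on these data alone, is whether the rise comes from the methoxy group specifically or would follow from replacing fluoro with other groups, such as a hydroxyl, an amine or a longer chain like ethoxy, at this same place. Also open, as far as these compounds go, is whether the same exchange of fluoro for methoxy would give a step of similar size on a different carbon of the ring.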